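This account rests on a few compounds, and the source may have more. Where it says the series, first, only, none or still open, it means among the compounds named here.

- Compound 1 `COc1ccc(/C=C/S(=O)(=O)Cc2ccc(OC)c(N)c2)cc1` gives 2500 nM
- Compound 2 `COC(=O)C(F)(F)Nc1cc(CS(=O)(=O)/C=C/c2c(OC)cc(OC)cc2OC)ccc1OC` gives 250 nM

These numbers come from a functional assay on K562 cells (Homo sapiens) for cytotoxicity, read by trypan blue exclusion, with a stated time of 96 h (a higher number here means a weaker inhibitor, a lower number a stronger inhibitor), and compound 2 (at 250 nM) is the lower of the two, with compound 1 at 2500 nM. The gap between the two lies beyond the scatter. Compound 3 `COc1cc(OC)c(/C=C/S(=O)(=O)Cc2ccc(OC)c(NCCC(=O)O)c2)c(OC)c1` has not yet been measured. Its change is 2-carboxyethyl in place of difluoro(methoxycarbonyl)methyl on a nitrogen on an aromatic ring. Among the measured compounds shown here, no measured step shows the effect of this change, so only a small shift is expected, an estimated 1.2-fold higher number from compound 2 to compound 3 (0.08 log units; within the scatter) in this assay (nothing beyond the scatter). Compound 3 is expected to give about 300 nM (estimated range 60 nM to 1500 nM).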

Compound 3, half-maximal inhibitory concentration: 5000 nM
Compound 3: the middle estimate sits 17-fold (1.22 log units) below what was measured; measured number outside the range, above it.
By their numbers in this assay, from the lowest: compound 2; then compounds 1 and 3 (each within the scatter of the next).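

In this assay the group on this nitrogen clearly matters: putting 2-carboxyethyl in place of difluoro(methoxycarbonyl)methyl gives a 20-fold higher number from compound 2 to compound 3 (1.30 log units; beyond the scatter), a large loss of strength. Among the compounds shown here, this is the first view of a change at this position, as compound 1 and compound 2 differ in more than one place. No measurement here accounts for the loss.

The compounds shown leave open which part of the change counts most. A 2-(methoxycarbonyl)ethyl or a difluoro(carboxy)methyl group on the same nitrogen would help separate the chain's end group from its fluorine atoms.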